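From furan-3-yl to 1-benzofuran-2-yl in compound 4

This account rests on a few compounds, and the source may have more. Where it says the series, first, only, none or still open, it means among the compounds named here.

In a functional assay on K562 cells (Homo sapiens), read by MTT assay, with a stated time of 72 h (on this read-out higher numbers stand for weaker inhibition and lower numbers for stronger inhibition), compound 3 (`Cc1ncnc2c1c(-c1ccoc1)cn2[C@@H]1O[C@H](CO)[C@@H](O)[C@H]1O`) reports only a limit, > 20000 nM. That limit recurs in the small set: the limit of > 20000 nM in this assay, at which 2 of the 3 values shown sit. Compound 4 (`Cc1ncnc2c1c(-c1cc3ccccc3o1)cn2[C@@H]1O[C@H](CO)[C@@H](O)[C@H]1O`) differs from it on an aromatic carbon: 1-benzofuran-2-yl in place of furan-3-yl on an aromatic carbon. Compound 1 (`COc1ncnc2c1c(-c1cc3ccccc3o1)cn2[C@@H]1O[C@H](CO)[C@@H](O)[C@H]1O`), which carries 1-benzofuran-2-yl, gives 20900 nM. Compound 2 (`CN(C)c1ncnc2c1c(-c1cc3ccccc3o1)cn2[C@@H]1O[C@H](CO)[C@@H](O)[C@H]1O`), with the same group, also reports only a limit, > 20000 nM. For the measured compounds named here, the sole measured step, a step that the limit leaves unreadable from compound 1 to compound 2, involves a different group and cannot be read, so no measured step tests this change directly. With compound 1 at 20900 nM, only a small move towards stronger inhibition is expected in this assay. The estimated step is an at least 1.3-fold lower number from compound 3 to compound 4 (0.12 log units; that floor lies within the scatter). The estimate for compound 4 is 15000 nM, with an expected range of 4000 nM to 40000 nM.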

Compound 4, half-maximal inhibitory concentration: 19500 nM
Compound 4: the middle estimate sits 1.3-fold (0.11 log units) below what was measured; measured number inside the range.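

In this assay, on these data alone, the change to 1-benzofuran-2-yl on this aromatic carbon can be read only as a floor (an at least 1.0-fold lower number from compound 3 to compound 4 (0.01 log units; that floor lies within the scatter)), so its true size stays unknown. With 1-benzofuran-2-yl held, methyl and methoxy read alike (a 1.1-fold lower number from compound 1 to compound 4 (0.03 log units; within the scatter)), while against dimethylamino only a floor is available (an at least 1.0-fold lower number from compound 2 to compound 4 (0.01 log units; that floor lies within the scatter)). Compound 4 gives a number, yet the series still sits close to a limit: the limit of > 20000 nM in this assay, at which 2 of the 4 values shown sit.

As far as these compounds go, how far compound 3 truly lies from compound 4 stays open. So does whether a primary amine or a carboxylic acid in place of methyl would move the number beyond the scatter.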